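Dichlorophenyl to trichlorophenyl on the oxygen-linked aryl ether

A few compounds are considered here, and "the series" means these few. Any claim that something is new, unique, unknown or untested is made for them only; others in the source may bear on it.

Working notes on a small set of diaminotriazine spiro ethers. Within the data shown here, compound 1 `NC1=NC2(CCSCC2)N(OCCCOc2cccc(Cl)c2Cl)C(N)=N1` is the only member with a measured number so far. In an assay on isolated protein for inhibition of Dihydrofolate reductase (Homo sapiens), read by spectrophotometry, using NADPH, with stated times of 5 s and 6 min, tested at 50 uM (a higher number here means a stronger effect of the compound at the concentration tested, a lower number a weaker effect), compound 1 gives 89.8%, which places it as the sole reference point in the set, with no second number to rank it against. Compound 2 `CC(C)(C)c1ccc(OCCCON2C(N)=NC(N)=NC23CCOCC3)cc1` belongs to the same series but in this assay compound 2 has "not determined" (no result reported), so it adds no number for comparison.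

Compound 3 `NC1=NC2(CCSCC2)N(OCCCOc2cc(Cl)c(Cl)cc2Cl)C(N)=N1` is the next entry to be measured in this assay. It differs from compound 1 at one place: 2,4,5-trichlorophenyl in place of 2,3-dichlorophenyl on an oxygen on a saturated carbon. Among the measured compounds shown here, no pair of measured compounds in this set shows a step of this kind, so the size of the change has to be judged without a measured precedent.

Given that compound 1 already shows 89.8%, the expected step of a number 2.2 percentage points higher from compound 1 to compound 3 (within the scatter) is small and within the usual scatter. For compound 3 the estimate in this assay is 92%, with a range from 80% to 99%.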

Compound 3, a percentage reported as inhibition, at one concentration (the size of the read-out at that concentration, not a potency): 94.4%
For compound 3 the middle estimate is 2.4 percentage points below the measured one; the measured number falls inside the stated range.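

In this assay, among these compounds, the exchange of 2,3-dichlorophenyl for 2,4,5-trichlorophenyl on an oxygen on a saturated carbon gives a number 4.6 percentage points higher from compound 1 to compound 3 (within the scatter) and provides the first measured step at this position, so the two compounds cannot be ordered on this read-out. The position therefore accepts this change, with nine heavy atoms in the aryl group in place of eight, and compound 3 gives 94.4% at the single concentration tested, a read-out that is not a potency and could conceal a difference in potency between the two compounds. No measurement is available that explains why the read-out holds across this change.

Because this single step changes both the number of chlorines and the pattern of substitution, the contribution of each remains unresolved. Also open, on these data alone, is how the read-out responds to a phenyl ring carrying a carboxylic acid or an amine instead of chlorine, or to a longer chain between the shared core and the aryl ether oxygen.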